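This account rests on a few compounds, and the source may have more. Where it says the series, first, only, none or still open, it means among the compounds named here.

Compound 1 `Fc1ccc(Nc2nc(-c3cccc(F)c3)nc3ccc(F)cc23)cc1` gives > 50000 nM in a functional assay on COLO 205 cells (Homo sapiens) for cytotoxicity, read by MTT assay, with a stated time of 48 h (on this read-out higher numbers stand for weaker inhibition and lower numbers for stronger inhibition), a limit of the assay.
Compound 2 `Fc1cccc(-c2nc(Nc3ccccc3F)c3cc(F)ccc3n2)c1` gives > 50000 nM in this assay, again a limit.
Compound 3 `Fc1cccc(-c2nc(Nc3cccc(Cl)c3)c3cc(F)ccc3n2)c1` gives > 50000 nM in this assay, again a limit.

Compound 1 stands only at a limit, as do the two other values shown; all three sit at the limit of > 50000 nM in this assay, at which 3 of the 3 values shown sit. Compound 4 `Fc1cccc(-c2nc(Nc3ccccc3Br)c3cc(F)ccc3n2)c1` differs from compound 1 by 2-bromophenyl in place of 4-fluorophenyl on a nitrogen on an aromatic ring. The measured steps that bear on this change are a step that the two limits leave unreadable from compound 1 to compound 2 and a step that the two limits leave unreadable from compound 1 to compound 3, with a step that the two limits leave unreadable from compound 2 to compound 3 between the other two; none of them is readable, so neither size nor direction can be taken from them. For compound 4 the value is expected to stay at the limit as well. That expectation amounts to a step of a number no higher from compound 1 to compound 4 (the limit leaves the size open). Compound 4 is therefore estimated at 50000 nM, with a range of 20000 nM to 200000 nM.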

Compound 4, half-maximal inhibitory concentration: > 50000 nM
Compound 4 ended at the assay's limit; the forecaster's own chance of this, stated with the estimate: 85%; the middle value lies on the limit itself.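

The steps from compounds 1, 2 and 3 to compound 4 cannot be read, as every value is a limit: the limit of > 50000 nM in this assay, at which 4 of the 4 values shown sit.

The compounds shown leave open which change, if any, would give a measurable value in this assay.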